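Propyl to methylsulfonyl on the aromatic nitrogen

This account rests on a few compounds, and the source may have more. Where it says the series, first, only, none or still open, it means among the compounds named here.

Measured in a functional assay on the whole organism with Mus musculus as the target; a higher number here means that more compound is needed for the effect, a lower number that less compound is needed:
- Compound 1 `Cc1c(C)c2c(c(C)c1NC=O)CC(C)(C)O2`: > 100 mg/kg (a limit)
- Compound 2 `CCCNc1c(C)c(C)c2c(c1C)CC(C)(C)O2`: 51.1 mg/kg

Among the measured compounds shown here, compound 2 stands alone as the only compound with an actual number, 51.1 mg/kg. Compound 1 gives only a limit, > 100 mg/kg.

Compound 3 `Cc1c(C)c2c(c(C)c1NS(C)(=O)=O)CC(C)(C)O2` has methylsulfonyl in place of propyl on a nitrogen on an aromatic ring, (methylsulfonyl in place of propyl on a nitrogen on an aromatic ring). For the measured compounds named here, the one measured step that bears on this is an at least 1.9-fold lower number from compound 1 to compound 2 (0.29 log units; that floor lies within the scatter), where propyl took the place of formyl. Compound 3 gives up the propyl again, so the expected direction in this assay is towards a higher number, though that measured step gives only a floor. The expected change from compound 2 is a 1.8-fold higher number from compound 2 to compound 3 (0.25 log units; within the scatter). A step beyond the scatter is therefore not firmly expected, and a result reported only as a limit remains possible. The estimated value for compound 3 is 90 mg/kg, with an expected range of 35 mg/kg to 230 mg/kg.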

Compound 3, dose for 50% inhibition: > 100 mg/kg
Compound 3: only a limit was reported; the forecaster's own chance of this, stated with the estimate: 45%; middle value at least 1.1-fold (0.04 log units) away from the limit.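

In this assay compound 3 gives > 100 mg/kg, which is a limit and not a number. Among the compounds shown here, replacing propyl with methylsulfonyl on this nitrogen gives an at least 1.9-fold higher number from compound 2 to compound 3 (0.29 log units; that floor lies within the scatter), so a real step beyond the scatter is not established, and propyl remains the only group on this nitrogen with a measured value. The step between compound 1 and compound 3 cannot be read, and formyl and methylsulfonyl share the same limit: the limit of > 100 mg/kg in this assay, at which 2 of the 3 values shown sit.

On these data alone, how far compound 3 actually lies from compound 2, and whether formyl and methylsulfonyl differ at all, remain open. A longer chain such as butyl, or a shorter one such as ethyl, on this nitrogen would show whether the measured value is particular to propyl or extends to other carbon chains.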